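The compounds below may be only part of what the source reports. "The series", "measured", "known", "first", "only" and "open" are said of these compounds alone.

Measured so far:
compound 1, `CC(C)[C@H](NC(=O)[C@]1(Cc2ccccc2)CCN1C(=O)OCc1ccccc1)C(N)=O`: > 100000 nM
compound 2, `C[C@H](NC(=O)[C@]1(Cc2ccccc2)CCN1S(=O)(=O)c1ccc2ccccc2c1)C(N)=O`: > 100000 nM
compound 3, `CC(C)[C@H](NC(=O)[C@@]1(Cc2ccccc2)CCN1C(=O)OCc1ccccc1)C(N)=O`: > 100000 nM

In an ADME assay on HELF cells (Homo sapiens) for cytotoxicity, with a stated time of 3 days (a lower number here means that less compound is tolerated, a higher number that more compound is tolerated), compound 1 stands at > 100000 nM, which is a limit of the assay and not a number. Compound 2 sits at a limit as well, > 100000 nM. Compound 3 also returns a limit, > 100000 nM. Among the compounds with values here, no measured compound therefore gives a readable value, and the one step within the measured set, a step that the two limits leave unreadable from compound 1 to compound 3, rests on two limits; the compounds of that step differ only in the configuration as drawn (the fact that compounds 1 and 3 differ only in the configuration as drawn).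

Compound 4 is `C[C@H](NC(=O)[C@]1(Cc2ccccc2)CCN1C(=O)OCc1ccccc1)C(=O)NCc1ccccc1`. Against compound 1 the change is 1-(benzylcarbamoyl)ethyl in place of 1-carbamoyl-2-methylpropyl on an amide-type nitrogen. Within the data shown here, no measured step touches this part of the structure: the only measured step concerns configuration at the ring carbon, not the amide-type nitrogen, so nothing of its size can be carried over. What can be said comes from the limit of > 100000 nM in this assay, at which 3 of the 3 values shown sit: every measured compound, with or without the sulfonyl group of compound 2, is tolerated up to the limit.

Compound 4 is therefore expected to behave like compound 1, with a step of a number no higher from compound 1 to compound 4 (the limit leaves the size open) not beyond the scatter. The estimate for compound 4 is 100000 nM, between 50000 nM and 300000 nM, most likely reported again as a limit.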

Compound 4, minimum cytotoxic concentration: 100000 nM
Estimate against measurement, compound 4: no gap at the digits printed; measured number inside the range.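

In this assay compound 4 gives 100000 nM, a plain number and the only readable value among the compounds shown. Compound 1 stands at > 100000 nM, which is a limit of the assay and not a number. On the amide-type nitrogen, 1-(benzylcarbamoyl)ethyl in place of 1-carbamoyl-2-methylpropyl gives a number no higher from compound 1 to compound 4 (the limit leaves the size open), so a change at this position, bringing a six-membered aromatic ring of carbon only into this group, still leaves the series at the top of the reported range: the limit of > 100000 nM in this assay, at which 3 of the 4 values shown sit.

The size of the step stays unreadable, and the compounds shown do not separate the added benzyl part from the loss of the 2-methylpropyl part, as both change together between compound 1 and compound 4. Going by these compounds, it also remains open whether a carboxylic acid or an amine in this group at the same nitrogen would give a readable value in this assay.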